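Fluoro for Bromo at the Edge of Measurement

The source may hold more compounds than are shown below. What is called first, only, known or untested is meant among the compounds shown, and "the series" means these compounds.

Compound 1 `Oc1cccc(/C=N/c2ccc(OCc3ccccc3)cc2)c1O` gives 13300 nM in a functional assay, with a stated time of 30 min; a higher number here means a weaker inhibitor, a lower number a stronger inhibitor. For compound 2 `Oc1ccc(Br)cc1/C=N/c1ccc(OCc2ccccc2)cc1` this assay reports only a limit, > 200000 nM. Compound 2 thus stands at the limit of > 200000 nM in this assay, at which 1 of the 2 values shown sits, with no number of its own. Compound 3 `Oc1ccc(F)cc1/C=N/c1ccc(OCc2ccccc2)cc1` carries fluoro in place of bromo on an aromatic carbon. Among the compounds with values here, the one measured step, an at least 15-fold higher number from compound 1 to compound 2 (1.17 log units; beyond the scatter), exchanges a whole substituted ring rather than one halogen for another, so no measured step bears directly on this change. Compound 3 is expected to remain near the limit reached by compound 2, a step that the limit leaves unreadable from compound 2 to compound 3 not beyond the scatter. The estimate for compound 3 is 250000 nM, within 50000 nM to 1000000 nM.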

Compound 3, half-maximal inhibitory concentration: > 200000 nM
Compound 3 ended at the assay's limit; the forecaster's own chance of this, stated with the estimate: 65%; the middle value lies beyond the limit too.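

In this assay, fluoro in place of bromo at this position still gives no number: compound 3 reports only a limit, > 200000 nM. With limits on both sides, the step between compound 2 and compound 3 cannot be read. The 5-fluoro-2-hydroxyphenyl group also stands far from the 2,3-dihydroxyphenyl group, with an at least 15-fold higher number from compound 1 to compound 3 (1.17 log units; beyond the scatter), so the large step seen with compound 2 is not confined to bromo: the limit of > 200000 nM in this assay, at which 2 of the 3 values shown sit.

As far as these compounds go, how far compound 2 and compound 3 lie past the limit stays open, as does any order between them. Also open, from the compounds shown here alone, is whether an amine or a carboxylic acid at this position would return a measurable value.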